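A few compounds are considered here, and "the series" means these few. Any claim that something is new, unique, unknown or untested is made for them only; others in the source may bear on it.

Compound 2 `COc1cc(/C=C/C(=O)/C=C/c2cc(OC)c(OC)c(OC)c2)ccc1OCc1cn(CCCCOc2cc(=O)oc3ccccc23)nn1` and compound 1 `COc1cc(/C=C/C(=O)/C=C/c2ccco2)ccc1OCc1cn(CCCCOc2cc(=O)oc3ccccc23)nn1` share one core. In a functional assay on HCT-116 cells (Homo sapiens) for inhibition, read by sulforhodamine B assay, with a stated time of 48 h, tested at 50 uM (on this read-out lower numbers stand for less inhibition of growth and higher numbers for more inhibition of growth at the one concentration tested), compound 2 gives 63%, while compound 1 gives 47%. The change between them is furan-2-yl in place of 3,4,5-trimethoxyphenyl on a double-bonded chain carbon bound to a double-bonded chain carbon, and it made a step of a number 16 percentage points lower from compound 2 to compound 1 (beyond the scatter). Compound 3 `COc1cc(/C=C/C(=O)/C=C/c2cc(OC)c(OC)c(OC)c2)ccc1OCc1cn(CCCCCOc2cc(=O)oc3ccccc23)nn1` has a core whose difference from the core of compound 2 is not broken down here; in this assay compound 3 gives 53%. Compound 4 `COc1cc(/C=C/C(=O)/C=C/c2ccco2)ccc1OCc1cn(CCCCCOc2cc(=O)oc3ccccc23)nn1` has not been measured and differs from compound 3 by furan-2-yl in place of 3,4,5-trimethoxyphenyl on a double-bonded chain carbon bound to a double-bonded chain carbon, the same change at the same place as before. The step to compound 4 is expected to be about as large as the earlier one, an expectation that rests on a single shown case, a number 16 percentage points lower from compound 2 to compound 1 (beyond the scatter), and is estimated at a number 16 percentage points lower from compound 3 to compound 4 (beyond the scatter). Compound 4 is thus expected to give roughly 37% in this assay.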

Compound 4, percent growth inhibition at one concentration: 37%
Compound 4: middle estimate and measured number agree at the digits printed; the measured number falls inside the stated range.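

In this assay the change to furan-2-yl from 3,4,5-trimethoxyphenyl gives a number 16 percentage points lower from compound 3 to compound 4 (beyond the scatter) and so carries over from one core to the other at much the same size: the same change on two cores in this assay, a number 16 percentage points lower (beyond the scatter) from compound 2 to compound 1 and a number 16 percentage points lower (beyond the scatter) from compound 3 to compound 4, 0 percentage points apart, within the scatter of two such steps. Going by these compounds alone, this agreement rests on only two cores, so it does not establish a rule for the whole series. It also does not show why growth inhibition falls, and it covers only one cell line at one concentration.

As far as these compounds go, whether the step would hold on a core with a longer chain remains open. So does the outcome of placing another group at this position, such as a phenyl ring bearing an amine or a carboxylic acid.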